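Cyclic peroxide acids: a stereoisomer step in growth inhibition

This account rests on a few compounds, and the source may have more. Where it says the series, first, only, none or still open, it means among the compounds named here.

Measured compounds:
compound 1 `CC(=O)CC/C=C(\C)CCC1=C(C)CCCC1(C)C` — 1860 nM
compound 2 `C=C1CCCC(C)(C)C1CC[C@]1(C)CC[C@@H]([C@@H](C)C(=O)O)OO1` — > 10000 nM, a limit
compound 3 `CC1=C(CC/C(C)=C/CC[C@@]2(C)CC[C@@H]([C@H](C)C(=O)O)OO2)C(C)(C)CCC1` — > 100000 nM, a limit

All values come from a functional assay on Hs-578T cells (Homo sapiens) for inhibition; a lower number here means a stronger inhibitor of growth, a higher number a weaker inhibitor of growth. Of the three, only compound 1 gives a number. Compound 2 gives a limit in this assay, > 10000 nM, so its position among the values is known only as sitting at the limit of > 10000 nM in this assay, at which 1 of the 3 values shown sits. Compound 3 also gives a limit, and it sits at the limit of > 100000 nM in this assay, at which 1 of the 3 values shown sits. Compound 2 therefore stands somewhere at or beyond the weak end of what is known here, without a number of its own.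

Compound 4 `C=C1CCCC(C)(C)C1CC[C@@]1(C)CC[C@H]([C@@H](C)C(=O)O)OO1` is not yet measured. Its relation to compound 2 is the two compounds have the same atoms and bonds; at least one stereo element is drawn with a configuration in one of them and without one in the other: 2 of 4 stereo elements differ; a stereocentre at a saturated ring carbon is drawn R in compound 2 and S in compound 4; a stereocentre at a saturated ring carbon is drawn S in compound 2 and R in compound 4. Among the measured compounds shown here, no step between measured compounds that differ in one place is available to calibrate what such a change does in this assay. The expectation is for no step beyond the scatter in this assay, because compound 2 already gives > 10000 nM and the change keeps every atom and bond. Compound 4 is expected near 12000 nM, with a range from 3000 nM to 40000 nM. That estimate means an expected step that the limit leaves unreadable from compound 2 to compound 4, within the scatter, and a limit rather than a number is the likelier outcome.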

Compound 4, concentration for 50% growth inhibition: 8740 nM
Compound 4: the middle estimate sits 1.4-fold (0.14 log units) above what was measured, and the stated range covers the measured number.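

Of the cyclic peroxide acids here, compound 4 alone gives a number in this assay, so a readable value is possible for this acid with its two ring stereocentres drawn as in compound 4 and every atom and bond unchanged. The stereo change gives an at least 1.1-fold lower number from compound 2 to compound 4 (0.05 log units; that floor lies within the scatter), and the real size of that step cannot be read from this floor. The only difference within this pair lies in the stereo drawing: the fact that one of compounds 2 and 4 is drawn with a defined configuration and the other without, at the place where they differ

Compound 2 remains a limit, > 10000 nM, in this assay, and a number for it would be needed to size the step. Open too, from the compounds shown here alone, are whether either ring stereocentre alone accounts for the step, and how a methyl ester or a primary amide in place of the carboxylic acid would read on the core of compound 4.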